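Inverting one stereocentre of compound 3

The source may hold more compounds than are shown below. What is called first, only, known or untested is meant among the compounds shown, and "the series" means these compounds.

In a functional assay on HeLa cells (Homo sapiens) for cytotoxicity, read by colorimetric assay and neutral red uptake, with a stated time of 72 h (on this read-out lower numbers stand for stronger inhibition and higher numbers for weaker inhibition), compound 1 `CO[C@@H](C(=O)N[C@H]1CCCCNC1=O)[C@H](O)[C@@H](O)[C@H](O)/C=C/C(C)(C)C` gives 60700 nM, compound 2 `CO[C@@H](C(=O)N[C@@H]1CCCCNC1=O)[C@H](O)[C@@H](O)[C@H](O)/C=C/C(C)(C)C` gives 2100 nM and compound 3 `CO[C@@H](C(=O)N[C@@H]1CC[C@@H](O)CNC1=O)[C@H](O)[C@@H](O)[C@H](O)/C=C/C(C)(C)C` gives 15400 nM. Compound 3 therefore stands in the middle of the three numbers, weaker than compound 2 and stronger than compound 1.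

Compound 4 `CO[C@@H](C(=O)N[C@@H]1CC[C@H](O)CNC1=O)[C@H](O)[C@@H](O)[C@H](O)/C=C/C(C)(C)C` is still unmeasured. Among the measured compounds shown here, its single structural change is the two compounds have the same atoms and bonds and differ only in configuration as drawn: 1 of 7 stereo elements differ; a stereocentre at a saturated ring carbon is drawn R in compound 3 and S in compound 4.

Two kinds of measured step bear on this change. The only purely stereochemical one is large, a 29-fold lower number from compound 1 to compound 2 (1.46 log units; beyond the scatter), and it arises because of the fact that compounds 1 and 2 differ only in the configuration as drawn. It shows that configuration alone can move the number far in this series, but it concerns another stereocentre, so it gives no direction here. The hydroxy steps are modest: a 3.9-fold lower number from compound 1 to compound 3 (0.60 log units; beyond the scatter) and a 7.3-fold higher number from compound 2 to compound 3 (0.87 log units; beyond the scatter). Compound 3 lies well above compound 2 at 2100 nM, which leaves room for a move towards lower numbers, while a move upwards cannot be excluded.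

In this assay a modest step towards a lower number is expected, with low confidence in its direction. The estimated step is a 2.2-fold lower number from compound 3 to compound 4 (0.34 log units; beyond the scatter). The estimated value for compound 4 is 7000 nM, with an expected range of 2000 nM to 30000 nM.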

Compound 4, half-maximal inhibitory concentration: > 150000 nM
Compound 4 ended at the assay's limit; the forecaster's own chance of this, stated with the estimate: 5%; middle value at least 21-fold (1.33 log units) from the limit.
By their numbers in this assay, from the lowest: compound 2; then compound 3; then compound 1. At a limit, above all of these: compound 4.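

In this assay compound 4 reads > 150000 nM, which is a limit of the assay and not a number. The earlier compounds shown here showed configuration mattering only at the other stereocentre, whereas inverting the ring carbon that carries the hydroxy also moves the number, with an at least 9.7-fold higher number from compound 3 to compound 4 (0.98 log units; beyond the scatter); the two compounds share all atoms and bonds, so this step traces to configuration alone: the fact that compounds 3 and 4 differ only in the configuration as drawn. Adding the hydroxy to compound 2 is far more damaging with this carbon drawn S, at an at least 71-fold higher number from compound 2 to compound 4 (1.85 log units; beyond the scatter), than with it drawn R, at a 7.3-fold higher number from compound 2 to compound 3 (0.87 log units; beyond the scatter), and against compound 1 the direction reverses, from a 3.9-fold lower number from compound 1 to compound 3 (0.60 log units; beyond the scatter) to an at least 2.4-fold higher number from compound 1 to compound 4 (0.39 log units; beyond the scatter).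

The series does not settle whether the loss belongs to the S hydroxy specifically or to any group on this carbon drawn S, a question that a methoxy or an amine on the same ring carbon, in both configurations, would address. Going by these compounds, how far the value of compound 4 lies past the limit also stays open, so the true sizes of its three steps remain unknown.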